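The compounds below may be only part of what the source reports. "The series", "measured", "known", "first", "only" and "open" are said of these compounds alone.

The shared core of the series appears in compound 1 `CCCCc1cn(C[C@H](O)[C@H]2OC(=O)C(OCc3ccccc3)=C2OCc2ccccc2)nn1`, which carries a butyl group on the five-membered aromatic ring with three nitrogens. In a functional assay on HCT-116 cells (Homo sapiens) for antiproliferative activity, read by MTT assay, with a stated time of 72 h (a lower number here means a stronger inhibitor, a higher number a weaker inhibitor), compound 1 gives 10400 nM. Compound 2 `CC(C)(C)c1cn(C[C@H](O)[C@H]2OC(=O)C(OCc3ccccc3)=C2OCc2ccccc2)nn1` bears a tert-butyl group there, and in this assay compound 2 gives 28300 nM; the change brought a 2.7-fold higher number from compound 1 to compound 2 (0.43 log units; beyond the scatter). Compound 3 `Cc1ccc(-c2cn(C[C@H](O)[C@H]3OC(=O)C(OCc4ccccc4)=C3OCc3ccccc3)nn2)cc1` carries a 4-methylphenyl group instead. For compound 3 this assay reports only the limit > 100000 nM and no number, as recorded in the limit of > 100000 nM in this assay, at which 1 of the 3 values shown sits. Moving from the alkyl groups to this aryl group gave an at least 9.6-fold higher number from compound 1 to compound 3 (0.98 log units; beyond the scatter) and an at least 3.5-fold higher number from compound 2 to compound 3 (0.54 log units; beyond the scatter). Compound 4 `O=C1O[C@H]([C@@H](O)Cn2cc(-c3cc(F)cc(F)c3)nn2)C(OCc2ccccc2)=C1OCc1ccccc1` differs from compound 3 by 3,5-difluorophenyl in place of 4-methylphenyl on an aromatic carbon. Among the measured compounds shown here, both measured steps reaching compound 3 swap an alkyl for an aryl group and weaken inhibition; no measured step swaps one aryl for another, so compound 4 is expected to stay near the limit. Compound 4 is therefore estimated at 120000 nM, within 35000 nM to 400000 nM, an expected step that the limit leaves unreadable from compound 3 to compound 4.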

Compound 4, half-maximal inhibitory concentration: 48200 nM
Compound 4: middle estimate off by 2.5-fold (0.40 log units), on the high side; the measured number falls inside the stated range.
By their numbers in this assay, from the lowest: compound 1; then compounds 2 and 4 (each within the scatter of the next). At a limit, above all of these: compound 3.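

Compound 4 shows that this position, on an aromatic carbon of a five-membered aromatic ring with 3 nitrogen, can carry an aryl group and still give a number in this assay: the change from 4-methylphenyl to 3,5-difluorophenyl brought an at least 2.0-fold lower number from compound 3 to compound 4 (0.31 log units; beyond the scatter). Aryl groups therefore do not all fall together here; the new group brought a 1.7-fold higher number from compound 2 to compound 4 (0.23 log units; within the scatter), so it cannot be ranked against tert-butyl, while butyl keeps its lead, with a 4.6-fold higher number from compound 1 to compound 4 (0.67 log units; beyond the scatter). The size of the first step remains a bound, since compound 3 has no number: the limit of > 100000 nM in this assay, at which 1 of the 4 values shown sits.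

Going by these compounds, it remains open whether the difference from compound 3 follows from the two fluorines or from the loss of the methyl group. Also open, on these data alone, is how an unsubstituted phenyl, a single fluorine, a methoxy group or a chain longer than butyl would fare at this position.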